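The source may report more compounds than this note shows. Statements on the series, on what has been measured and on what is new or still open speak of the compounds shown alone.

Of the compounds shown here, three of one shared core have been measured in a functional assay on MKN-45 cells (Homo sapiens) for cytotoxicity, read by MTT assay, with a stated time of 72 h; on this read-out higher numbers stand for weaker inhibition and lower numbers for stronger inhibition. Compound 1 `COc1cc2c(Oc3ccc(NC(=O)c4cn(-c5ccccc5OC)cn4)cc3F)ccnc2cc1OCCCN1CCN(C)CC1` gives 220 nM, compound 2 `COc1cc2c(Oc3ccc(NC(=O)c4cn(-c5cc(C)ccc5C)cn4)cc3F)ccnc2cc1OCCCN1CCN(C)CC1` gives 650 nM, and compound 3 `COc1cc2c(Oc3ccc(NC(=O)c4cn(-c5ccccc5OC(F)(F)F)cn4)cc3F)ccnc2cc1OCCCN1CCCCC1` gives 190 nM, the lowest of the three numbers, within the scatter of compound 1 and beyond it only against compound 2. Compound 4 `COc1cc2c(Oc3ccc(NC(=O)c4cn(-c5ccc(Cl)cc5Cl)cn4)cc3F)ccnc2cc1OCCCN1CCCCC1` has not yet been measured; it differs from compound 3 in one place: 2,4-dichlorophenyl in place of 2-(trifluoromethoxy)phenyl on an aromatic nitrogen. Among the measured compounds shown here, the one measured step that bears on this, a change of the phenyl group on the same aromatic nitrogen, is a 3.0-fold higher number from compound 1 to compound 2 (0.47 log units; beyond the scatter). A modest rise of similar size is therefore expected, a 2.4-fold higher number from compound 3 to compound 4 (0.37 log units; beyond the scatter). Compound 4 is estimated at 450 nM, with a range from 180 nM to 1100 nM.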

Compound 4, half-maximal inhibitory concentration: 6240 nM
Compound 4: middle estimate off by 14-fold (1.14 log units), on the low side, outside the stated range (above it).
By their numbers in this assay, from the lowest: compounds 3 and 1 (each within the scatter of the next); then compound 2; then compound 4.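

In this assay, this change on the aromatic nitrogen gives a 33-fold higher number from compound 3 to compound 4 (1.52 log units; beyond the scatter), a large step beside the modest 3.0-fold higher number from compound 1 to compound 2 (0.47 log units; beyond the scatter) from another change of phenyl group at the same place. This position therefore does not accept every substituted phenyl group equally, and the choice of group can matter far more than the first pair suggested. No measurement here explains the size of this step.

From the compounds shown here alone, it remains open whether the rise goes with one chlorine or with both. A plain phenyl group or a monochlorophenyl group at this place could help separate the two.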